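The compounds below may be only part of what the source reports. "The series", "measured", "known", "first", "only" and "open" are said of these compounds alone.

Of the compounds shown here, two have been measured in a functional assay on HeLa cells (Homo sapiens) for antiproliferative activity, read by CCK-8 assay, with a stated time of 72 h, tested at 2 uM; a lower number here means a weaker effect, a higher number a stronger effect of the compound at the concentration tested. Compound 1, `Nc1ccccc1NC(=O)c1ccc(CSC(=S)N2CCN(c3ccc(Cl)cc3)CC2)cc1`, gives 51.2% in this assay. Within the data shown here, compound 2, `CCN(Cc1ccncc1)C(=S)SCc1ccc(C(=O)Nc2ccccc2N)cc1`, gives 63.5% in this assay, the higher of the two numbers measured so far, with compound 1 standing lower by a gap beyond the usual scatter. Among the measured compounds shown here, no step between two measured compounds that differ in a single place is available, so the two values can only be set side by side.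

Compound 3, `CN1CCN(C(=S)SCc2ccc(C(=O)Nc3ccccc3N)cc2)CC1`, has not yet been measured. Relative to compound 2 it differs in one place: 4-methylpiperazin-1-yl in place of ethyl((pyridin-4-yl)methyl)amino on a thiocarbonyl carbon. The two measured compounds offer no direct guide to what this change does, since neither of them shares it. For the measured compounds named here, with no comparable step to lean on, the author expects compound 3 to fall somewhat below compound 2, by a step in this assay of a number 11.5 percentage points lower from compound 2 to compound 3 (beyond the scatter), a shift that may or may not exceed the scatter. Accordingly compound 3 is estimated to give 52% in this assay, within a range from 32% to 70%.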

Compound 3, a percentage reported as inhibition, at one concentration (the size of the read-out at that concentration, not a potency): 52.6%
Compound 3: middle estimate off by 0.6 percentage points, on the low side; low and high end bracket the measured number.
By their numbers in this assay, from the lowest: compounds 1 and 3 (each within the scatter of the next); then compound 2.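

In this assay, the change on a thiocarbonyl carbon whose other neighbours are sulfur now has a measured effect: 4-methylpiperazin-1-yl in place of ethyl((pyridin-4-yl)methyl)amino gives a number 10.9 percentage points lower from compound 2 to compound 3 (beyond the scatter), a modest step beyond the scatter at the single concentration tested. By contrast, methyl in place of 4-chlorophenyl on an amine nitrogen in a ring gives a number 1.4 percentage points higher from compound 1 to compound 3 (within the scatter), so this assay does not separate those two groups, despite the difference between an aromatic ring and a single carbon. No measurement at hand accounts for either step.

The compounds shown leave open which part of ethyl((pyridin-4-yl)methyl)amino goes with the higher number, the ethyl group or the pyridin-4-ylmethyl group, as the step exchanges both at once. From the compounds shown here alone, it also remains open whether the insensitivity seen on the ring nitrogen would hold for other groups there, such as an acetyl group, a benzyl group or a longer alkyl chain, or whether a morpholine ring on the thiocarbonyl carbon would read like 4-methylpiperazin-1-yl.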